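This account rests on a few compounds, and the source may have more. Where it says the series, first, only, none or still open, it means among the compounds named here.

Three measured compounds share most of their structure and differ only in the ring that ends the chain. In a functional assay on MIA PaCa-2 cells (Homo sapiens) for antiproliferative activity, read by MTT assay, with a stated time of 72 h (a higher number here means a weaker inhibitor, a lower number a stronger inhibitor), compound 3 `COCn1c(=O)[nH]c(CC(COCc2ccccc2)COCc2ccccc2)c(C)c1=O` gives 27300 nM, the lower of the two real numbers. Compound 2 `COCn1c(CC(COCc2ccccc2)COCc2ccccc2)c(C)c(=O)[nH]c1=O`, an isomer, gives 55900 nM, a difference beyond the usual scatter. Compound 1 `COc1cc(CC(O)(COCc2ccccc2)COCc2ccccc2)nc(OC)n1`, with a different ring, reaches only a limit, > 100000 nM. That limit is the limit of > 100000 nM in this assay, at which 1 of the 3 values shown sits. Compound 4 `COCn1c(CC(COCc2ccccc2)COCc2ccccc2)c(C)c(=O)n(COC)c1=O` carries methoxymethyl in place of hydrogen on an aromatic nitrogen. Going by the values given here, no measured pair mirrors this change, so the expected step is small, leaning toward a weaker inhibitor and possibly within the scatter. The expected step of a 1.4-fold higher number from compound 3 to compound 4 (0.14 log units; within the scatter) carries that view. For compound 4 the estimated value is 38000 nM, with a likely range from 12000 nM to 100000 nM.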

Compound 4, half-maximal inhibitory concentration: 500 nM
For compound 4 the middle estimate is 76-fold (1.88 log units) above the measured one; measured number outside the range, below it.
By their numbers in this assay, from the lowest: compound 4; then compound 3; then compound 2. At a limit, above all of these: compound 1.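

In this assay, placing a methoxymethyl in place of hydrogen on the remaining aromatic nitrogen gives a 55-fold lower number from compound 3 to compound 4 (1.74 log units; beyond the scatter) and a 110-fold lower number from compound 2 to compound 4 (2.05 log units; beyond the scatter). Both large steps end at the same compound, so the gain is reached from either isomer, and a free hydrogen on this nitrogen is not required for activity. No measurement shown gives a cause for this gain. The compounds shown leave open whether losing the hydrogen is enough or the methoxymethyl itself matters. A plain methyl, a longer chain or an amine-bearing chain on this nitrogen could help separate the two.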